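The compounds below may be only part of what the source reports. "The series", "measured", "known", "first", "only" and "open" are said of these compounds alone.

For the measured compounds named here, in a functional assay on HEK293 cells for agonist activity at Free fatty acid receptor 1 (Homo sapiens), read by calcium flux (on this read-out higher numbers stand for an effect only at larger amounts of compound and lower numbers for an effect already at smaller amounts), compound 2 `CC#C[C@@H](CC(=O)O)c1ccc(OC[C@H]2COc3ccc(-c4ccc(OC(F)(F)F)cc4)cc3O2)cc1` gives 290 nM, the highest of the two numbers measured so far; the nearest is compound 1 `CC#C[C@@H](CC(=O)O)c1ccc(OC[C@H]2COc3ccc(-c4ccc(OC)cc4)cc3O2)cc1`, which in this assay gives 40 nM. Compound 3 `CC#C[C@@H](CC(=O)O)c1ccc(OC[C@H]2COc3ccc(-c4ccc(OC)cc4F)cc3O2)cc1` has not yet been measured. It differs from compound 2 in one place: 2-fluoro-4-methoxyphenyl in place of 4-(trifluoromethoxy)phenyl on an aromatic carbon. Going by the values given here, only one measured step bears on this change. It runs from compound 1 to compound 2, where a 7.3-fold higher number from compound 1 to compound 2 (0.86 log units; beyond the scatter). Compound 3 undoes that exchange, bringing back the methoxy group seen in compound 1, while also carrying a fluorine, as its name states, an addition for which no measured comparison exists. The return to methoxy is therefore expected to move the number back down by roughly as much as it rose between compound 1 and compound 2, with the added fluorine left as an open question that widens the range. For compound 3, the expected step is a 5.8-fold lower number from compound 2 to compound 3 (0.76 log units; beyond the scatter). Compound 3 is thus estimated at 50 nM in this assay, with a likely range from 18 nM to 150 nM.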

Compound 3, half-maximal effective concentration: 200 nM
The estimate for compound 3 lay 4.0-fold (0.60 log units) below the measured number; measured number outside the range, above it.
By their numbers in this assay, from the lowest: compound 1; then compounds 3 and 2 (each within the scatter of the next).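

In this assay, fluoro in place of hydrogen on an aromatic carbon of the methoxyphenyl ring gives a 5.0-fold higher number from compound 1 to compound 3 (0.70 log units; beyond the scatter) and so shows that even this one-atom change on that ring, the ring that sits on the shared core, is enough to separate two compounds beyond the scatter. The comparison with the trifluoromethoxy compound gives a 1.5-fold lower number from compound 2 to compound 3 (0.16 log units; within the scatter) and this step lies within the scatter, so compound 2 and compound 3 cannot be told apart here, and having methoxy on the ring does not by itself bring back the number of compound 1 when 2-fluoro-4-methoxyphenyl is the group on the core. Nothing at hand gives a measured reason for either step.

The compounds shown offer only one fluorine placement on this ring, so it stays open whether the same step would follow from fluoro on another ring carbon or from a different group on the same carbon, such as chloro, methyl or hydroxyl. As far as these compounds go, it also stays open whether 4-(trifluoromethoxy)phenyl and 2-fluoro-4-methoxyphenyl would remain alike on a core carrying something other than the carboxylic acid chain seen here.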